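The source may report more compounds than this note shows. Statements on the series, on what has been measured and on what is new or still open speak of the compounds shown alone.

Of the compounds shown here, two have been measured in a functional assay on 786-0 cells (Homo sapiens) for inhibition, read by sulforhodamine B assay, with a stated time of 48 h; a lower number here means a stronger inhibitor of growth, a higher number a weaker inhibitor of growth. Compound 1, `CC1=CC[C@H](C(C)(C)N=C=S)CC1`, gives only a limit of the assay, > 100000 nM. Compound 2, `CC1=CC[C@H](C(C)(C)NC(=S)N/N=C/c2ccc(O)cc2)CC1`, likewise gives only a limit, > 100000 nM. Compound 2 therefore stands at the limit of > 100000 nM in this assay, at which 2 of the 2 values shown sit, and no real number places it anywhere within the range the assay can report. Compound 3, `CC1=CC[C@H](C(C)(C)NC(=S)N/N=C/c2ccc(F)cc2)CC1`, differs from compound 2 in one place: fluoro in place of hydroxy on an aromatic carbon. Within the data shown here, no step between measured compounds exists here to guide the direction of this change, and both measured values are limits, so nothing in the numbers points up or down. The step expected in this assay is a number no higher from compound 2 to compound 3 (the limit leaves the size open), none beyond the usual scatter. Compound 3 is accordingly estimated at about 100000 nM in this assay, within a range from 30000 nM to 300000 nM, and most probably again only a limit.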

Compound 3, concentration for total growth inhibition: > 100000 nM
Compound 3 was reported as a limit; the forecaster's own chance of this, stated with the estimate: 80%; the middle value lies on the limit itself.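

No new step can be read between compound 2 and compound 3, since both are reported only as limits: the limit of > 100000 nM in this assay, at which 3 of the 3 values shown sit.

The compounds shown leave open what real growth-inhibition value any of them has in this assay, and whether 4-hydroxyphenyl and 4-fluorophenyl differ there at all.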